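Swapping a Dimethylamino Chain End for a Hydroxyl

The source may hold more compounds than are shown below. What is called first, only, known or untested is meant among the compounds shown, and "the series" means these compounds.

Of the compounds shown here, two built on the same sulfamate-bearing core have been measured in an assay on HEK293 cells for inhibition of Steryl-sulfatase (Homo sapiens), tested at 1 uM; a lower number here means a weaker effect, a higher number a stronger effect of the compound at the concentration tested. Compound 1, `NS(=O)(=O)Oc1ccc2c(c1)CN(C(=O)c1ccc(N3CCN(Cc4ccccc4)CC3)cc1)CC2`, gives 75.8% in this assay. Compound 2, `CN(C)CCCN(Cc1ccccc1)c1cccc(C(=O)N2CCc3ccc(OS(N)(=O)=O)cc3C2)c1`, gives 26%, the lower of the two numbers and separated from compound 1 by a gap well beyond the scatter.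

Compound 3, `NS(=O)(=O)Oc1ccc2c(c1)CN(C(=O)c1cccc(N(CCCO)Cc3ccccc3)c1)CC2`, has not yet been measured. It is derived from compound 2 by a single change: hydroxy in place of dimethylamino on a saturated chain carbon, three bonds along the chain from a nitrogen on an aromatic ring. Among the compounds with values here, no measured pair in this set differs in exactly this way, so there is no earlier step to lean on, and compound 1 differs from compound 2 in several places at once.

With that in mind, the step from compound 2 to compound 3 in this assay is expected to be small, a number 2 percentage points higher from compound 2 to compound 3 (within the scatter), and may not rise beyond the scatter. For compound 3 the estimate is 28%, with a range from 5% to 55%.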

Compound 3, a percentage reported as inhibition, at one concentration (the size of the read-out at that concentration, not a potency): 37.3%
Beside the measured number, compound 3's estimate is 9.3 percentage points below it, and the stated range covers the measured number.
By their numbers in this assay, from the lowest: compound 2; then compound 3; then compound 1.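

In this assay, putting hydroxy in place of dimethylamino on this chain gives a real, though modest, change, with a number 11.3 percentage points higher from compound 2 to compound 3 (beyond the scatter). So this chain end affects the read-out, and the dimethylamino group is not needed there to keep the inhibition seen with compound 2, since the smaller hydroxy, which adds a hydrogen-bond donor, does better. The data shown offer no measurement that explains this gain.

The change removes dimethylamino and adds a donor in one step, so the two cannot be told apart here; a methoxy group or a primary amine at the same chain end would help to separate them. As far as these compounds go, whether the 3-hydroxypropyl chain has the best length also remains open, and a 2-hydroxyethyl or a longer 4-hydroxybutyl chain would address that.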